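Furan to pyrrole in a potent imidazoline ether

The source may report more compounds than this note shows. Statements on the series, on what has been measured and on what is new or still open speak of the compounds shown alone.

Compound 1 `c1ccc(-c2ccncc2)c(OCC2=NCCN2)c1` gives < 100000 nM in a functional assay for activation of Alpha-1A adrenergic receptor (Homo sapiens), read by calcium flux; a higher number here means that more compound is needed for the effect, a lower number that less compound is needed; this is a limit of the assay, not a number. Compound 2 `c1coc(-c2ccccc2OCC2=NCCN2)c1` gives 1.26 nM in this assay.

Among the compounds with values here, compound 2 therefore stands as the only real number here; the other value is a limit (the limit of < 100000 nM in this assay, at which 1 of the 2 values shown sits). Within the data shown here, the single measured step, from compound 1 to compound 2, is a step that the limit leaves unreadable from compound 1 to compound 2, so it shows that the furan partner works far better than the pyridine partner but gives no readable size.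

Compound 3 `c1c[nH]c(-c2ccccc2OCC2=NCCN2)c1` differs from compound 2 only in this way: 1H-pyrrol-2-yl in place of furan-2-yl on an aromatic carbon. Among the measured compounds shown here, no measured step bears readably on such a swap of one five-membered ring for another, so the expectation rests on compound 2 alone and allows for some loss. Compound 3 is expected to sit at 5 nM, within 0.8 nM to 40 nM, an estimated step of a 4.0-fold higher number from compound 2 to compound 3 (0.60 log units; beyond the scatter).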

Compound 3, half-maximal effective concentration: 1.26 nM
Beside the measured number, compound 3's estimate is 4.0-fold (0.60 log units) above it, within the range that was stated.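

In this assay, putting 1H-pyrrol-2-yl in place of furan-2-yl on the aromatic carbon gives no change at the digits printed from compound 2 to compound 3 (within the scatter). This swap exchanges a ring oxygen for a ring nitrogen carrying a hydrogen, and so a hydrogen-bond acceptor for a hydrogen-bond donor, yet the two compounds read alike, so at this position the pair does not distinguish between the two rings. The steps from compound 1 cannot be read, since compound 1 carries a limit of the assay and not a number: the limit of < 100000 nM in this assay, at which 1 of the 3 values shown sits.

Two rings are too few to show whether five-membered aromatic rings in general work at this position. On these data alone, it also remains open how thiophen-2-yl, with sulfur as its ring hetero atom, or a non-aromatic group such as an amine or a longer chain would read on the same carbon.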